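The source may hold more compounds than are shown below. What is called first, only, known or untested is meant among the compounds shown, and "the series" means these compounds.

Measured so far, in an ADME assay for metabolic stability, read by LC-MS, with a stated time of 3 h, at pH 6.5, tested at 50 uM; on this read-out higher numbers stand for a more stable compound and lower numbers for a less stable compound:
Compound 1, `CC(C)OC(=O)OCOC(=O)C1=C(S[C@@H]2CN[C@H](C(=O)Nc3cccc(C(=O)O)c3)C2)[C@H](C)[C@@H]2[C@@H]([C@@H](C)O)C(=O)N12`, gives > 95%, which is a limit of the assay rather than a number.
Compound 2, `CCOC(=O)OCOC(=O)C1=C(S[C@@H]2CN[C@H](C(=O)Nc3cccc(C(=O)O)c3)C2)[C@H](C)[C@@H]2[C@@H]([C@@H](C)O)C(=O)N12`, gives > 95%, again a limit of the assay.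
Compound 3, `CC(C)OC(=O)c1cccc(NC(=O)[C@@H]2C[C@H](SC3=C(C(=O)O)N4C(=O)[C@H]([C@@H](C)O)[C@H]4[C@H]3C)CN2)c1`, gives > 95%, also a limit of the assay.

Compound 1 and compound 2 differ in one place: hydrogen in place of methyl on a saturated chain carbon bound to an oxygen next to a carbonyl group and a saturated chain carbon. The size of the step that the two limits leave unreadable from compound 1 to compound 2 cannot be read, because of the limit of > 95% in this assay, at which 3 of the 3 values shown sit. Compound 3 carries a different core; the difference between the core of compound 1 and the core of compound 3 is not broken down here.

Compound 4, `CCOC(=O)c1cccc(NC(=O)[C@@H]2C[C@H](SC3=C(C(=O)O)N4C(=O)[C@H]([C@@H](C)O)[C@H]4[C@H]3C)CN2)c1`, has not yet been tested in this assay. Within the data shown here, it differs from compound 3 in just one place, (hydrogen in place of methyl on a saturated chain carbon bound to an oxygen next to a carbonyl group and a saturated chain carbon), which is the same change, at the same kind of place, as the one from compound 1 to compound 2. Since the same change did not move the read-out off the limit, because of the limit of > 95% in this assay, at which 3 of the 3 values shown sit, the step from compound 3 to compound 4 is expected to be flat, a step that the limit leaves unreadable from compound 3 to compound 4. Compound 4 is therefore estimated at 96%, expected to lie between 88% and 99%, most likely again as a limit.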

Compound 4, percent of the compound remaining: > 95%
Compound 4 gave a limit, no number; the forecaster's own chance of this, stated with the estimate: 0.8%; the middle value is on the limit's open side.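

Compound 3 and compound 4 both give only a limit of the assay, so the step between them cannot be read, because no value here is an actual number: the limit of > 95% in this assay, at which 4 of the 4 values shown sit.

The compounds shown leave open whether the change from isopropyl to ethyl moves the read-out in this assay at all.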